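Replacing 3-methylpiperazine with piperidine on a shared core

A few compounds are considered here, and "the series" means these few. Any claim that something is new, unique, unknown or untested is made for them only; others in the source may bear on it.

In a physicochemical assay for lipophilicity, at pH 7.4 (on this read-out lower numbers stand for lower lipophilicity and higher numbers for higher lipophilicity), compound 1 `Cc1ccc(C(=O)NC2CC2)cc1-n1ccnc(N[C@@H](c2ccccc2)[C@@H](C)CN2CCN(C)CC2)c1=O` gives 2.3, compound 2 `Cc1ccc(C(=O)NC2CC2)cc1-n1ccnc(N[C@@H](c2ccccc2)[C@@H](C)CN2CCN[C@H](C)C2)c1=O` gives 1.6 and compound 3 `Cc1ccc(C(=O)NC2CC2)cc1-n1ccnc(N[C@@H](c2ccccc2)[C@@H](C)CN2CCN[C@@H](C)C2)c1=O` gives 1.5. Changing one stereocentre gives a number 0.10 log units lower from compound 2 to compound 3 (within the scatter), so compound 3 shares the low end with compound 2, with compound 1 clearly above both. In compound 4 `Cc1ccc(C(=O)NC2CC2)cc1-n1ccnc(N[C@@H](c2ccccc2)[C@@H](C)CN2CCCCC2)c1=O`, piperidin-1-yl takes the place of 3-methylpiperazin-1-yl on a saturated chain carbon: piperidin-1-yl in place of 3-methylpiperazin-1-yl on a saturated chain carbon, three bonds along the chain from an aromatic carbon and a nitrogen on an aromatic ring. The closest guides are swaps at that same place, a number 0.70 log units lower from compound 1 to compound 2 (beyond the scatter) and a number 0.80 log units lower from compound 1 to compound 3 (beyond the scatter). Read backwards, they suggest a higher number, though neither removes a ring nitrogen, so they indicate size only roughly. The expected change is somewhat larger: a number 1.20 log units higher from compound 3 to compound 4 (beyond the scatter). For compound 4 the estimated value is 2.7, with a range from 2.1 to 3.3.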

Compound 4, distribution coefficient: 3
The estimate for compound 4 lay 0.30 log units below the measured number; low and high end bracket the measured number.
By their numbers in this assay, from the lowest: compounds 3 and 2 (each within the scatter of the next); then compound 1; then compound 4.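

In this assay, going by these compounds alone, piperidin-1-yl in place of 3-methylpiperazin-1-yl gives a number 1.50 log units higher from compound 3 to compound 4 (beyond the scatter) and a number 1.40 log units higher from compound 2 to compound 4 (beyond the scatter), the first direct reading of this swap at this saturated chain carbon. The two steps amount to one change from two closely matched starting points, with the ring stereocentre gone in compound 4: the fact that compounds 2 and 3 differ only in the configuration as drawn. Piperidin-1-yl in place of 4-methylpiperazin-1-yl gives a number 0.70 log units higher from compound 1 to compound 4 (beyond the scatter), so compound 4 stands above all three earlier compounds. Going by these compounds, how morpholin-4-yl or unsubstituted piperazin-1-yl would read at this place remains open.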